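A Dichlorophenyl Swap on Compound 1

The compounds below may be only part of what the source reports. "The series", "measured", "known", "first", "only" and "open" are said of these compounds alone.

Among the compounds with values here, in a functional assay on HepG2 cells (Homo sapiens) for antiproliferative activity, read by MTT assay, with a stated time of 72 h (on this read-out lower numbers stand for stronger inhibition and higher numbers for weaker inhibition), compound 1 `NC1=NC2(CCSCC2)N(OCCCOc2ccc(Cl)c(Cl)c2)C(N)=N1` gives 70 nM and holds the lower of the two numbers measured so far. Compound 2 `NC1=NC2(CCOCC2)N(OCCCOc2cccc(Cl)c2Cl)C(N)=N1` gives 330 nM there, a higher number by a gap beyond the usual scatter. Compound 3 `NC1=NC2(CCSCC2)N(OCCCOc2cccc(Cl)c2Cl)C(N)=N1` has not yet been measured. It keeps the core of compound 1 and has 2,3-dichlorophenyl in place of 3,4-dichlorophenyl on an oxygen on a saturated carbon and nothing else changes. Within the data shown here, no step between measured compounds isolates this change. Among the measured compounds shown here, the only guide is compound 2, which also carries 2,3-dichlorophenyl and gives 330 nM in this test. In this assay a moderate rise in the number is therefore expected, an estimated 2.4-fold higher number from compound 1 to compound 3 (0.39 log units; beyond the scatter) and so probably a little beyond the scatter. Compound 3 is estimated at 170 nM in this test, with an expected range from 60 nM to 480 nM given the thin evidence.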

Compound 3, half-maximal inhibitory concentration: 50 nM
Beside the measured number, compound 3's estimate is 3.4-fold (0.53 log units) above it; the whole stated range lies above it.
By their numbers in this assay, from the lowest: compounds 3 and 1 (each within the scatter of the next); then compound 2.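

In this assay, the two dichlorophenyl groups on an oxygen on a saturated carbon cannot be told apart on the core of compound 1: a 1.4-fold lower number from compound 1 to compound 3 (0.15 log units; within the scatter). The 2,3-dichlorophenyl group therefore does not by itself go with a number like that of compound 2, 330 nM, since the core of compound 1 carries the same group in compound 3, and compound 3 gives 50 nM. No supporting data are available to explain this result.

From the compounds shown here alone, it remains open whether 3,4-dichlorophenyl would give a similar number on the core of compound 2, and whether 3,5-dichlorophenyl or a phenyl ring with a single chlorine would match these values at this position. Also open, going by these compounds, is how a longer chain on the same oxygen, or a methoxy or trifluoromethyl group in place of a chlorine, would change the number.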